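Working notes: bromo in place of cyano on compound 3

This account rests on a few compounds, and the source may have more. Where it says the series, first, only, none or still open, it means among the compounds named here.

- Compound 1 `CN(C)c1ccc(-c2nc3c(N4CCN(CC(=O)Nc5cccnc5)CC4)c(Br)cnc3[nH]2)cc1` – 1650 nM
- Compound 2 `O=C(CN1CCN(c2c(Br)cnc3[nH]c(-c4ccccc4)nc23)CC1)Nc1nccs1` – 3000 nM
- Compound 3 `CN(C)c1ccc(-c2nc3c(N4CCN(CC(=O)Nc5nccs5)CC4)c(C#N)cnc3[nH]2)cc1` – 1030 nM

In a functional assay on HCT-116 cells (Homo sapiens) for inhibition, read by MTT assay, with a stated time of 72 h (a lower number here means a stronger inhibitor of growth, a higher number a weaker inhibitor of growth), compound 3 gives 1030 nM and sits within the scatter of compound 1 at 1650 nM while compound 2 at 3000 nM lies beyond the scatter from it, with a higher number.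

Compound 4 `CN(C)c1ccc(-c2nc3c(N4CCN(CC(=O)Nc5nccs5)CC4)c(Br)cnc3[nH]2)cc1` remains unmeasured in this assay and differs from compound 3 in one place: bromo in place of cyano on an aromatic carbon with the rest of the structure unchanged. No measured pair isolates this change, so its size is not shown directly. Compound 1 carries bromo and gives 1650 nM within the scatter of compound 3. Compound 2 also carries bromo and gives 3000 nM but differs from compound 4 elsewhere as well.

The expected step is small and toward a higher number, within the scatter, with a 1.4-fold higher number from compound 3 to compound 4 (0.13 log units; within the scatter) as the estimate. Compound 4 is estimated at 1400 nM with 650 nM to 3000 nM as the expected range.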

Compound 4, concentration for 50% growth inhibition: 480 nM
Compound 4: middle estimate off by 2.9-fold (0.46 log units), on the high side; the whole stated range lies above it.
By their numbers in this assay, from the lowest: compound 4; then compounds 3, 1 and 2 (each within the scatter of the next, the first and the last beyond it).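

In this assay, going by these compounds alone, bromo in place of cyano on this aromatic carbon, ortho to a large group, gives a 2.1-fold lower number from compound 3 to compound 4 (0.33 log units; beyond the scatter) as the first single-change reading at this position. With bromo held fixed, dimethylamino in place of hydrogen on an aromatic carbon gives a 6.3-fold lower number from compound 2 to compound 4 (0.80 log units; beyond the scatter) and 1,3-thiazol-2-yl in place of pyridin-3-yl on an amide-type nitrogen gives a 3.4-fold lower number from compound 1 to compound 4 (0.54 log units; beyond the scatter) in the same assay. The higher numbers of the two earlier bromo compounds therefore do not count against bromo here, since each of them also differs from the best-matched compound at another place.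

On these data alone, only bromo and cyano can be compared at this position, so how chloro, methyl or plain hydrogen would read there remains open. Nothing at hand explains the step from cyano to bromo.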